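Bromo for Methyl in a Cytotoxicity Series

A few compounds are considered here, and "the series" means these few. Any claim that something is new, unique, unknown or untested is made for them only; others in the source may bear on it.

- compound 1 `FC(F)(F)c1ccc(NCc2cn(-c3ccccc3)nc2-c2ccc(Br)cc2)cc1`: 28000 nM
- compound 2 `Cc1ccc(-c2nn(-c3ccccc3)cc2CNc2ccc(Br)cc2)cc1`: 92000 nM

Both compounds were tested in an ADME assay on Vero 76 cells (Chlorocebus sabaeus) for cytotoxicity, read by MTT assay, with a stated time of 96 h; on this read-out higher numbers stand for lower toxicity in this test and lower numbers for higher toxicity in this test. There compound 2, at 92000 nM, holds the higher of the two numbers, and compound 1, at 28000 nM, lies lower by a gap beyond the usual scatter.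

The next compound is compound 3 `Brc1ccc(NCc2cn(-c3ccccc3)nc2-c2ccc(Br)cc2)cc1`. It differs from compound 2 as follows: bromo in place of methyl on an aromatic carbon. In words, 4-methylphenyl becomes 4-bromophenyl.

Within the data shown here, no measured pair isolates this change, so the expectation rests on little. Compound 1, at 28000 nM, also carries the 4-bromophenyl, which points towards a lower number. The expected change is therefore a moderate drop, a 2.2-fold lower number from compound 2 to compound 3 (0.34 log units; beyond the scatter), though this estimate is uncertain. For compound 3 the expected value in this assay is 42000 nM, with an estimated range from 18000 nM to 95000 nM.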

Compound 3, half-maximal cytotoxic concentration: 88000 nM
The estimate for compound 3 lay 2.1-fold (0.32 log units) below the measured number; the range from low to high includes it.
By their numbers in this assay, from the lowest: compound 1; then compounds 3 and 2 (each within the scatter of the next).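

In this assay, the exchange of methyl for bromo on this aromatic carbon, para to a large group, gives a 1.0-fold lower number from compound 2 to compound 3 (0.02 log units; within the scatter), so carrying the 4-bromophenyl does not by itself go with the lower number of compound 1. That lower number tracks the other place instead: bromo in place of trifluoromethyl on an aromatic carbon gives a 3.1-fold higher number from compound 1 to compound 3 (0.50 log units; beyond the scatter), a modest step beyond the scatter. Nothing among the data explains either step.

The compounds shown leave open whether an amine or a carboxylic acid on the same aromatic carbon would also leave the number unmoved. They also leave open whether the trifluoromethyl-to-bromo step would keep its size with the 4-methylphenyl in place of the 4-bromophenyl.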